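The source may report more compounds than this note shows. Statements on the series, on what has been measured and on what is new or still open speak of the compounds shown alone.

Working notes on the series. In an ADME assay on HCT-116 cells (Homo sapiens) for antiproliferative activity (on this read-out higher numbers stand for weaker inhibition and lower numbers for stronger inhibition), compound 1 `CCc1ccc(OC)c(COc2ccc(Cl)c(C)c2)c1` gives 43000 nM, compound 2 `COc1ccc(C(N)=O)cc1/C=C/c1ccc(Cl)cc1` gives 7100 nM and compound 3 `COc1ccc(C(N)=O)cc1/C=C\c1ccc(Cl)cc1` gives 29000 nM. Compound 2 therefore holds the lowest of the three numbers, with compound 3 the nearest to it and compound 1 the furthest.

Going by the values given here, the only measured step between close neighbours is a 4.1-fold higher number from compound 2 to compound 3 (0.61 log units; beyond the scatter), and what separates that pair is the fact that compounds 2 and 3 differ only in the configuration as drawn. Compound 4 `COc1ccc(C(N)=O)cc1/C=C/c1ccc(Br)cc1` is the next one to read. It keeps the double bond as drawn in compound 2 and changes the halogen: bromo in place of chloro on an aromatic carbon. In words, this is bromo in place of chloro on an aromatic carbon, para to a large group.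

Among the compounds with values here, no measured step changes this halogen, so there is no direct size to carry over. The step of a 4.1-fold higher number from compound 2 to compound 3 (0.61 log units; beyond the scatter) concerns the double bond alone and bears on the new compound only by marking compound 2, at 7100 nM, as the reference. No change beyond the scatter is expected in this assay, so the estimated step is small, a 1.1-fold lower number from compound 2 to compound 4 (0.04 log units; within the scatter). For compound 4 the expected value is 6500 nM, with an estimated range of 3000 nM to 14000 nM.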

Compound 4, half-maximal inhibitory concentration: 22000 nM
The estimate for compound 4 lay 3.4-fold (0.53 log units) below the measured number, outside the stated range (above it).
By their numbers in this assay, from the lowest: compound 2; then compounds 4, 3 and 1 (each within the scatter of the next).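

In this assay the halogen on an aromatic carbon, para to a large group, is not a neutral place in this series: with the double bond kept as drawn in compound 2, bromo in place of chloro gives a 3.1-fold higher number from compound 2 to compound 4 (0.49 log units; beyond the scatter), and the number moves towards weaker inhibition. The series thus has a second single-place change beyond the scatter, alongside the change in double-bond configuration, a 4.1-fold higher number from compound 2 to compound 3 (0.61 log units; beyond the scatter), so both the halogen and the configuration register in this read-out. Nothing available on the compounds accounts for the step from chloro to bromo, and the only supporting observation concerns the double bond, not the halogen.

The compounds shown leave open how fluoro, methyl, methoxy or an amine would read at this same place, and so whether the step follows any trend across substituents or is particular to bromo. They also leave open whether bromo in place of chloro carries a step of similar size on the Z double bond of compound 3.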